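The compounds below may be only part of what the source reports. "The series", "measured", "known", "first", "only" and "open" are said of these compounds alone.

Working notes on the series, all read in an ADME assay on THP-1 cells (Homo sapiens) for cytotoxicity, read by trypan blue exclusion, with a stated time of 48 h; a lower number here means a stronger inhibitor of growth, a higher number a weaker inhibitor of growth. Compound 1 (`Cc1cc(CNOCc2ccccc2)c(C)n1-c1ccc(Cl)cc1`) gives 67 ug/mL, compound 2 (`Cc1cc(CN2CCN(C3C[C@@H]4CC[C@H]3C4)CC2)c(C)n1-c1ccc(Cl)cc1`) gives 16 ug/mL, and compound 3 (`Cc1cc(CN2CCN(c3ccccc3)CC2)c(C)n1-c1ccc(Cl)cc1`) gives 25 ug/mL. Compound 3 therefore sits within the scatter of compound 2, and the values of both lie under that of compound 1.

The next member is compound 4 (`Cc1cc(CN2CCN(C3CCCCC3)CC2)c(C)n1-c1ccc(Cl)cc1`), with cyclohexyl in place of phenyl on an amine nitrogen in a ring. Within the data shown here, only one measured step bears on this change. Compound 2 carries a non-aromatic carbon ring group on that nitrogen where compound 3 carries phenyl, and the step is a 1.6-fold higher number from compound 2 to compound 3 (0.19 log units; within the scatter). This single step is thin support, and it shows no change beyond the scatter, so none is expected here in this assay. The expected step is a 1.3-fold lower number from compound 3 to compound 4 (0.10 log units; within the scatter). For compound 4 the estimated value is 20 ug/mL, with an expected range of 10 ug/mL to 40 ug/mL.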

Compound 4, concentration for 50% growth inhibition: 16 ug/mL
Estimate against measurement, compound 4: 1.3-fold (0.10 log units) above; the measured number falls inside the stated range.
By their numbers in this assay, from the lowest: compounds 2, 4 and 3 (each within the scatter of the next); then compound 1.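

The direct exchange on the amine nitrogen in a ring, with the heavy atom count unchanged, now has its own reading: in this assay, cyclohexyl in place of phenyl gives a 1.6-fold lower number from compound 3 to compound 4 (0.19 log units; within the scatter). The comparison of cyclohexyl with the group of two five-membered non-aromatic rings gives no change at the digits printed from compound 2 to compound 4 (within the scatter), so all three groups on this nitrogen, aromatic or not and with one ring system or two, lie within the scatter of one another in this assay. No supporting measurement bears on these readings.

As far as these compounds go, whether an amine or a carboxylic acid on the cyclohexyl ring, or a longer chain in place of the ring, would stay within the same scatter remains open. From the compounds shown here alone, whether a group as small as methyl on this nitrogen would hold the number in this range also remains open.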